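Swapping hydroxy for amino on the shared core

A few compounds are considered here, and "the series" means these few. Any claim that something is new, unique, unknown or untested is made for them only; others in the source may bear on it.

Compound 1 `COc1ccc(NS(=O)(=O)/C=C/c2c(OC)cc(OC)cc2OC)cc1` gives 100 nM
Compound 2 `COc1cc(OC)c(/C=C/S(=O)(=O)Nc2ccc(OC)c(O)c2)c(OC)c1` gives 100 nM

Both values come from a functional assay on OVCAR-3 cells (Homo sapiens) for cytotoxicity, read by trypan blue exclusion, with a stated time of 96 h (on this read-out higher numbers stand for weaker inhibition of growth and lower numbers for stronger inhibition of growth), where compound 2 stands level with compound 1 and has no other neighbour. Compound 3 `COc1cc(OC)c(/C=C/S(=O)(=O)Nc2ccc(OC)c(N)c2)c(OC)c1` has not yet been measured. It departs from compound 2 at one place, with amino in place of hydroxy on an aromatic carbon, ortho to a methoxy group and meta to a large group (amino in place of hydroxy on an aromatic carbon). Within the data shown here, only one measured step bears on this carbon: hydroxy in place of hydrogen gave no change at the digits printed from compound 1 to compound 2 (within the scatter). Among the measured compounds shown here, no measured step yet shows amino on this core, so the expectation rests on that single small step. Accordingly, no shift beyond the scatter and no particular direction is expected in this assay, and the estimate is a 1.3-fold lower number from compound 2 to compound 3 (0.10 log units; within the scatter). Compound 3 is estimated at 80 nM, with an expected range from 30 nM to 250 nM.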

Compound 3, concentration for 50% growth inhibition: 4 nM
Estimate against measurement, compound 3: 20-fold (1.30 log units) above; the measured number lies below the stated range.
By their numbers in this assay, from the lowest: compound 3; then compounds 1 and 2 (each within the scatter of the next).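

The carbon ortho to a methoxy group is not indifferent to what it carries: in this assay, amino in place of hydroxy gives a 25-fold lower number from compound 2 to compound 3 (1.40 log units; beyond the scatter), and amino in place of hydrogen gives a 25-fold lower number from compound 1 to compound 3 (1.40 log units; beyond the scatter). Hydroxy had shown nothing of the kind, with no change at the digits printed from compound 1 to compound 2 (within the scatter), so amino and hydroxy, though matched in heavy atoms and in counted hydrogen-bond donors and acceptors, are not interchangeable at this carbon. No measurement at hand accounts for the difference between the two groups.

The compounds shown leave open how a methylamino group, a dimethylamino group or an acetamide would fare on this carbon. They also leave open whether the step seen with amino would hold on any core other than the shared one.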